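Shifting the hydroxyl group around the shared core

This account rests on a few compounds, and the source may have more. Where it says the series, first, only, none or still open, it means among the compounds named here.

Measured compounds:
compound 1 `Oc1ccc(-c2cc(-c3ccccc3)nc(-c3ccccc3Cl)c2)cc1`: 2800 nM
compound 2 `Oc1ccc(-c2cc(-c3ccncc3)nc(-c3ccccc3Cl)c2)cc1`: "not determined" (no result reported)
compound 3 `Oc1ccc(-c2cc(-c3ccsc3)nc(-c3ccccc3Cl)c2)cc1`: 3890 nM

In a functional assay on DU-145 cells (Homo sapiens) for cytotoxicity, read by CCK-8 assay and cell counting, with a stated time of 2 days (on this read-out lower numbers stand for stronger inhibition and higher numbers for weaker inhibition), compound 1 gives 2800 nM, the lowest of the two numbers reported, while compound 3 lies within the scatter of it, as the step of a 1.4-fold higher number from compound 1 to compound 3 (0.14 log units; within the scatter) shows. Compound 2 has no reported result.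

Compound 4 `Oc1cccc(-c2cc(-c3ccccc3)nc(-c3ccccc3Cl)c2)c1` differs from compound 1 by 3-hydroxyphenyl in place of 4-hydroxyphenyl on an aromatic carbon. Among the compounds with values here, no measured step moves the hydroxyl group; the only step known, a 1.4-fold higher number from compound 1 to compound 3 (0.14 log units; within the scatter), swaps a ring elsewhere on the core and stays within the scatter. Since the two structures share every atom, a change not beyond the scatter is expected, with the number for compound 4 estimated at 3500 nM (range 1500 nM to 9000 nM), a step of a 1.3-fold higher number from compound 1 to compound 4 (0.10 log units; within the scatter).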

Compound 4, half-maximal inhibitory concentration: 1480 nM
Estimate against measurement, compound 4: 2.4-fold (0.37 log units) above; the measured number lies below the stated range.
By their numbers in this assay, from the lowest: compounds 4, 1 and 3 (each within the scatter of the next, the first and the last beyond it).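

Within the data shown here, this is the first measured change at this position: in this assay, 3-hydroxyphenyl in place of 4-hydroxyphenyl gives a 1.9-fold lower number from compound 1 to compound 4 (0.28 log units; within the scatter), so the two placements of the hydroxyl group cannot be told apart here. Even with the same atoms joined differently, the result stays within the usual variation between repeat measurements. Nothing at hand explains the result or links it to a property of either group.

The compounds shown all carry a hydroxyl group on this ring, so whether the activity depends on it remains open. As far as these compounds go, how an amine, a methoxy group or a carboxylic acid would behave in its place also remains unknown.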